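The source may report more compounds than this note shows. Statements on the series, on what has been measured and on what is new or still open speak of the compounds shown alone.

Measured so far in a functional assay for inhibition of sodium/hydrogen exchanger (Oryctolagus cuniculus); on this read-out lower numbers stand for stronger inhibition and higher numbers for weaker inhibition:

Compound 1 `Cc1c(C(=O)N=C(N)N)cc(S(C)(=O)=O)c(Cl)c1Cl`, where compound 1 gives 29 nM
Compound 2 `CCN(CC)Cc1cc(Br)c(S(C)(=O)=O)cc1C(=O)N=C(N)N`, where compound 2 gives 9500 nM
Compound 3 `CCSc1cc(C)c(C(=O)N=C(N)N)cc1S(C)(=O)=O`, where compound 3 gives 5.9 nM

Among these three, compound 3 stands lowest in this assay, which here means the strongest inhibition. Its nearest neighbour is compound 1, whose number is higher by a margin beyond the usual scatter, and compound 2 lies far further away, a much weaker inhibitor. Among the compounds with values here, no two of the measured compounds differ in only one place, so no single structural step has been measured directly.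

Compound 4 `Cc1cc(Oc2ccc(Cl)cc2)c(S(C)(=O)=O)cc1C(=O)N=C(N)N` has not been measured yet. Compared with compound 3, the difference is 4-chlorophenoxy in place of ethylsulfanyl on an aromatic carbon. The group that enters is larger than the one that leaves. Within the data shown here, none of the measured compounds shows how this assay responds to such a change at this position, so the expectation is a cautious one. A moderate weakening is expected, a step of a 10-fold higher number from compound 3 to compound 4 (1.01 log units; beyond the scatter) that would reach beyond the scatter. Compound 4 is therefore estimated at 60 nM, with a range from 10 nM to 400 nM.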

Compound 4, half-maximal inhibitory concentration: 13 nM
Estimate against measurement, compound 4: 4.6-fold (0.66 log units) above; the measured number falls inside the stated range.
By their numbers in this assay, from the lowest: compound 3; then compound 4; then compound 1; then compound 2.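

Exchanging ethylsulfanyl for 4-chlorophenoxy on the aromatic carbon ortho to a methylsulfonyl group gives a 2.2-fold higher number from compound 3 to compound 4 (0.34 log units; beyond the scatter) in this assay, a modest loss of inhibition. This position therefore accepts a clearly larger group, one that brings an aromatic ring of its own, at only a small cost in this read-out. The data shown offer no measurement that explains why the cost is so small.

Within the data shown here, with only this one step at this position, it stays open how much of the result belongs to the chlorine, to the aromatic ring, or to the oxygen that links the ring to the core. A plain phenoxy group, a phenylsulfanyl group or a longer chain such as butylsulfanyl on the same carbon would help separate these parts.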